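The source may report more compounds than this note shows. Statements on the series, on what has been measured and on what is new or still open speak of the compounds shown alone.

Working notes on the amide-nitrogen substituent of the shared core. Compound 1 `Cc1ccc(OCC(=O)N(Cc2cccs2)c2ccncc2)cc1` gives 52 nM in an assay on HEK293 cells for agonist activity at transient receptor potential cation channel subfamily M member 8 (Homo sapiens), read by fluorescence and calcium flux, with a stated time of 15 min; a higher number here means that more compound is needed for the effect, a lower number that less compound is needed; compound 2 `Cc1ccc(OCC(=O)N(Cc2cccs2)c2ncccn2)cc1` gives 3700 nM; compound 3 `Cc1ccc(OCC(=O)N(CCCO)Cc2cccs2)cc1` gives 3000 nM, the second highest of the three numbers, close to compound 2 and far from compound 1. Compound 4 `Cc1ccc(OCC(=O)N(Cc2cccs2)c2cnccn2)cc1` carries pyrazin-2-yl in place of 3-hydroxypropyl on an amide-type nitrogen. Among the measured compounds shown here, the steps that bear on it are a 58-fold higher number from compound 1 to compound 3 (1.76 log units; beyond the scatter), a 71-fold higher number from compound 1 to compound 2 (1.85 log units; beyond the scatter) and a 1.2-fold lower number from compound 2 to compound 3 (0.09 log units; within the scatter); a six-membered diazine on this nitrogen and the 3-hydroxypropyl chain both sit far from the pyridin-4-yl of compound 1, and a second diazine is expected to fall between those levels, with a step of a 5.0-fold lower number from compound 3 to compound 4 (0.70 log units; beyond the scatter) in this assay. Compound 4 is therefore estimated at 600 nM, within 120 nM to 3000 nM.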

Compound 4, half-maximal effective concentration: 1240 nM
Compound 4: the middle estimate sits 2.1-fold (0.32 log units) below what was measured, and the stated range covers the measured number.
By their numbers in this assay, from the lowest: compound 1; then compound 4; then compounds 3 and 2 (each within the scatter of the next).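

On the amide-type nitrogen, the two diazines are not interchangeable in this assay: pyrazin-2-yl in place of pyrimidin-2-yl gives a 3.0-fold lower number from compound 2 to compound 4 (0.47 log units; beyond the scatter), so the ring type alone does not set the number. Pyrazin-2-yl in place of 3-hydroxypropyl gives a 2.4-fold lower number from compound 3 to compound 4 (0.38 log units; beyond the scatter), yet pyrazin-2-yl in place of pyridin-4-yl still gives a 24-fold higher number from compound 1 to compound 4 (1.38 log units; beyond the scatter). No measurement at hand accounts for these differences.

Open, going by these compounds, is how far the number depends on the count or the placing of the ring nitrogens. A phenyl or pyridin-3-yl ring on this nitrogen would bear on that.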